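Methylcarbamoyl to trifluoromethylcarbonyl on a shared core

The compounds below may be only part of what the source reports. "The series", "measured", "known", "first", "only" and "open" are said of these compounds alone.

Three compounds share one core and differ only in the group attached to one of its aromatic carbons. Compound 1 `N#Cc1cccc(-c2cnc(C(=O)CCCCCCc3ccccc3)o2)c1` gives 15 nM in an assay (Rattus norvegicus) for inhibition of Fatty-acid amide hydrolase 1 (Homo sapiens); a lower number here means a stronger inhibitor, a higher number a weaker inhibitor. Compound 2 `Cc1cccnc1-c1cnc(C(=O)CCCCCCc2ccccc2)o1` gives 15 nM in this assay, and no change at the digits printed from compound 1 to compound 2 (within the scatter). Compound 3 `CNC(=O)c1cnc(C(=O)CCCCCCc2ccccc2)o1` carries a methylcarbamoyl group and gives 7 nM in this assay; this is the lowest number of the three, with a 2.1-fold lower number from compound 1 to compound 3 (0.33 log units; beyond the scatter) and a 2.1-fold lower number from compound 2 to compound 3 (0.33 log units; beyond the scatter).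

Compound 4 `O=C(CCCCCCc1ccccc1)c1ncc(C(=O)C(F)(F)F)o1` has not yet been measured. Against compound 3 the change is trifluoromethyl in place of methylamino on a carbonyl carbon. The measured steps all exchange whole groups at the aromatic carbon; none of them replaces a methylamino group on a carbonyl carbon by a trifluoromethyl group, so they bear on this step only loosely. What they do show is that varied groups at that position keep the numbers close together, with the largest shift being modest. The expectation for compound 4 is therefore a number not far from that of compound 3. The step of a 1.4-fold higher number from compound 3 to compound 4 (0.15 log units; within the scatter) is expected to stay close to the scatter, in either direction. Compound 4 is estimated at 10 nM in this assay, expected to lie between 2 nM and 50 nM.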

Compound 4, inhibition constant: 4 nM
Beside the measured number, compound 4's estimate is 2.5-fold (0.40 log units) above it; the range from low to high includes it.
By their numbers in this assay, from the lowest: compounds 4 and 3 (each within the scatter of the next); then compounds 1 and 2 (each within the scatter of the next).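

Replacing methylamino with trifluoromethyl on the carbonyl carbon gives a 1.8-fold lower number from compound 3 to compound 4 (0.24 log units; within the scatter) in this assay, so at this position the group carrying a hydrogen-bond donor and the group carrying none cannot be told apart in this read-out. Compound 4 also stands clearly apart from the two compounds with a ring at the aromatic carbon, with a 3.8-fold lower number from compound 2 to compound 4 (0.57 log units; beyond the scatter) and a 3.8-fold lower number from compound 1 to compound 4 (0.57 log units; beyond the scatter); among these four compounds, the two with a carbonyl group at that carbon have the lower numbers, and none goes against this. No measurement shown here explains why the numbers of the two carbonyl-bearing compounds lie so close together.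

From the compounds shown here alone, whether other groups on that carbonyl carbon would stay in the same range remains open, for example the hydroxyl of a carboxylic acid, the methoxy of a methyl ester, or a plain methyl. Going by these compounds, all four compounds also share the same chain ending in a phenyl ring, so it remains unknown whether this picture would hold with a shorter chain.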